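The source may hold more compounds than are shown below. What is called first, only, known or untested is meant among the compounds shown, and "the series" means these compounds.

Of the compounds shown here, two have been tested in an ADME assay on HEK293 cells (Homo sapiens) for cytotoxicity, read by MTT assay, with a stated time of 48 h; on this read-out lower numbers stand for stronger inhibition and higher numbers for weaker inhibition. Compound 1 `CC1(C)CCCC2=CC=C(C=O)CC[C@]21C` gives 696000 nM. Going by the values given here, compound 2 `C=C1CCC[C@]2(C)CCC(c3cn(-c4ccc(OC)cc4)nn3)=CC[C@@]12C` gives 410000 nM, a number that lies within the usual scatter of the one for compound 1, so the two cannot be told apart. Compound 3 `C=C1CCC[C@]2(C)CCC(c3cn(-c4ccc(C(C)=O)cc4)nn3)=CC[C@@]12C` is not yet measured; it differs from compound 2 by acetyl in place of methoxy on an aromatic carbon. Among the compounds with values here, no measured pair shows this change, so there is nothing to lean on, and in this assay only a step no larger than the scatter is expected, in either direction. For compound 3 the expected step from compound 2 is a 1.2-fold lower number from compound 2 to compound 3 (0.07 log units; within the scatter). Compound 3 is therefore estimated at 350000 nM, between 150000 nM and 800000 nM.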

Compound 3, half-maximal inhibitory concentration: 520000 nM
Compound 3: the middle estimate sits 1.5-fold (0.17 log units) below what was measured; the measured number falls inside the stated range.
By their numbers in this assay, from the lowest: compounds 2, 3 and 1 (each within the scatter of the next).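

In this assay, putting acetyl in place of methoxy on this aromatic carbon, para to a large group, gives a 1.3-fold higher number from compound 2 to compound 3 (0.10 log units; within the scatter), so the two compounds cannot be told apart. Going by these compounds alone, this is the first direct look at a change at this position, and swapping one group for the other, with one more heavy atom, leaves no readable difference. No measurement at hand explains this result. The compounds shown leave open whether an amine or a carboxylic acid at this position would shift the number beyond the usual scatter.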